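Hydroxamate chain length on an anilinoquinazoline acrylamide series

The compounds below may be only part of what the source reports. "The series", "measured", "known", "first", "only" and "open" are said of these compounds alone.

Compound 1 `C=CC(=O)Nc1cc2c(Nc3ccc(OCc4cccc(F)c4)c(Cl)c3)ncnc2cc1OCc1cn(CCCCC(=O)NO)nn1` carries a 4-(hydroxycarbamoyl)butyl chain on its triazole. In a functional assay on NCI-H838 cells (Homo sapiens) for antiproliferative activity, read by MTT assay, with a stated time of 72 h (on this read-out lower numbers stand for stronger inhibition and higher numbers for weaker inhibition), compound 1 gives > 50000 nM, which is a limit of the assay. Compound 3 `C=CC(=O)Nc1cc2c(Nc3ccc(OCc4cccc(F)c4)c(Cl)c3)ncnc2cc1OCc1cn(CCC(=O)NO)nn1` differs from compound 1 by hydroxycarbamoyl in place of 2-(hydroxycarbamoyl)ethyl on a saturated chain carbon, two bonds along the chain from an aromatic nitrogen. In this assay compound 3 gives > 50000 nM, also a limit. The step that the two limits leave unreadable from compound 1 to compound 3 is therefore unreadable, because both values sit at the limit of > 50000 nM in this assay, at which 3 of the 3 values shown sit. Compound 2 `C=CC(=O)Nc1cc2c(Nc3cccc(Cl)c3F)ncnc2cc1OCc1cn(CCCCC(=O)NO)nn1` has a different core from compound 1; that difference is not broken down here. In this assay compound 2 gives > 50000 nM, a limit as well. Compound 4 `C=CC(=O)Nc1cc2c(Nc3cccc(Cl)c3F)ncnc2cc1OCc1cn(CCC(=O)NO)nn1` differs from compound 2 by hydroxycarbamoyl in place of 2-(hydroxycarbamoyl)ethyl on a saturated chain carbon, two bonds along the chain from an aromatic nitrogen, the same change as between compound 1 and compound 3. With all three measured values at the limit, the expected step that the limit leaves unreadable from compound 2 to compound 4 is essentially no change, resting on the unreadable a step that the two limits leave unreadable from compound 1 to compound 3. Compound 4 is estimated at 60000 nM, with a range from 20000 nM to 200000 nM.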

Compound 4, half-maximal inhibitory concentration: > 50000 nM
Compound 4 was reported as a limit; the forecaster's own chance of this, stated with the estimate: 85%; the middle value does not contradict the limit.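

No step can be read between compound 2 and compound 4, since both values are limits: the limit of > 50000 nM in this assay, at which 4 of the 4 values shown sit. From the compounds shown here alone, whether chain length or the core difference between compound 1 and compound 2 alters activity in this assay stays open.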